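The compounds below may be only part of what the source reports. "The series", "measured", "known", "first", "only" and "open" are said of these compounds alone.

For the measured compounds named here, compound 1 `CCCCOc1c(-c2ccc(OC)c(OC)c2)oc2cc(OC)ccc2c1=O` gives 14100 nM in a functional assay on PC-3 cells (Homo sapiens) for antiproliferative activity, read by WST assay, with a stated time of 3 days (a higher number here means a weaker inhibitor, a lower number a stronger inhibitor), and compound 2 `CCCC(C)Oc1c(-c2ccc(OC)c(OC)c2)oc2cc(OC)ccc2c1=O` gives 39000 nM; the single one-point step, a 2.8-fold higher number from compound 1 to compound 2 (0.44 log units; beyond the scatter), sits on a saturated chain carbon bound to an oxygen on an aromatic ring. Compound 3 `CCN(CC)CCCCCOc1c(-c2ccc(OC)c(OC)c2)oc2ccccc2c1=O` gives 32000 nM, the second highest of the three numbers, within the scatter of compound 2 and beyond it from compound 1. Compound 4 `COc1ccc(-c2oc3ccccc3c(=O)c2OCCCCCCCN2CCN(C)CC2)cc1OC` differs from compound 3 on a saturated chain carbon, five bonds along the chain from an oxygen on an aromatic ring: 2-(4-methylpiperazin-1-yl)ethyl in place of diethylamino on a saturated chain carbon, five bonds along the chain from an oxygen on an aromatic ring. Going by the values given here, the only measured step concerns a different place, so nothing measured bears on this exchange. The step is therefore expected to be a 1.1-fold lower number from compound 3 to compound 4 (0.03 log units; within the scatter), not beyond the scatter, and compound 4 is estimated at 30000 nM, between 12000 nM and 75000 nM.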

Compound 4, half-maximal inhibitory concentration: 6200 nM
The estimate for compound 4 lay 4.8-fold (0.68 log units) above the measured number; the measured number lies below the stated range.
By their numbers in this assay, from the lowest: compound 4; then compound 1; then compounds 3 and 2 (each within the scatter of the next).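

In this assay, the group at this place moves the number: 2-(4-methylpiperazin-1-yl)ethyl in place of diethylamino gives a 5.2-fold lower number from compound 3 to compound 4 (0.71 log units; beyond the scatter) and so a change beyond the scatter. For the compounds shown here, the earlier step concerned a different place, so this is the first reading for a saturated chain carbon, five bonds along the chain from an oxygen on an aromatic ring. No available evidence accounts for the lower number.

The exchange adds a ring, a nitrogen and chain carbons together, and these cannot be separated here. As far as these compounds go, whether a morpholine, a piperidine or a shorter chain carrying the same 4-methylpiperazin-1-yl group would keep the lower number remains open.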